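Chloro to Methyl in a Sulfonylurea Receptor Series

A few compounds are considered here, and "the series" means these few. Any claim that something is new, unique, unknown or untested is made for them only; others in the source may bear on it.

Compound 1 `CC(O)(C(=O)Nc1ccc(S(=O)(=O)c2ccccc2Cl)cc1)C(F)(F)F`: in a functional assay (Cavia porcellus) with sulfonylurea receptors; K-ATP channels (Homo sapiens) as the target (on this read-out lower numbers stand for stronger inhibition and higher numbers for weaker inhibition), compound 1 gives 2300 nM.
Compound 2 `Cc1ccccc1S(=O)(=O)c1ccc(NC(=O)C(C)(O)C(F)(F)F)cc1`: in this assay compound 2 gives 5100 nM.
Compound 3 `CC(O)(C(=O)Nc1ccc(C(=O)c2cccc(Cl)c2)cc1)C(F)(F)F`: in this assay compound 3 gives only a limit of the assay, > 30000 nM.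

Compound 1 and compound 2 differ by methyl in place of chloro on an aromatic carbon, and the step is a 2.2-fold higher number from compound 1 to compound 2 (0.35 log units; beyond the scatter). Compound 3 stands on a different core from compound 1; the difference between the two cores is not broken down here. For compound 3 only a limit is known, (the limit of > 30000 nM in this assay, at which 1 of the 3 values shown sits). Compound 4 `Cc1cccc(C(=O)c2ccc(NC(=O)C(C)(O)C(F)(F)F)cc2)c1`, not yet measured, differs from compound 3 by methyl in place of chloro on an aromatic carbon. This is the same kind of change as that from compound 1 to compound 2, but here the place is meta to a large group rather than ortho to a large group. Compound 4 is expected to stay at or beyond the limit, an estimated step that the limit leaves unreadable from compound 3 to compound 4, resting on the direction of a 2.2-fold higher number from compound 1 to compound 2 (0.35 log units; beyond the scatter). The estimate for compound 4 in this assay is 60000 nM, expected to fall between 25000 nM and 200000 nM.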

Compound 4, half-maximal inhibitory concentration: > 30000 nM
Compound 4 ended at the assay's limit; the forecaster's own chance of this, stated with the estimate: 85%; the middle value lies beyond the limit too.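

Compound 3 and compound 4 both sit at a limit of this assay, so no step between them can be read: the limit of > 30000 nM in this assay, at which 2 of the 4 values shown sit.

Going by these compounds, whether methyl in place of chloro changes the read-out on this core, as it does on the core of compound 1, stays open.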